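Series notes: amide-nitrogen substituent and antiproliferative read-out

This account rests on a few compounds, and the source may have more. Where it says the series, first, only, none or still open, it means among the compounds named here.

Measured so far:
compound 1 `CCn1c(C(=O)N[C@@H](CC(=O)OC)C(=O)OC)ccc1C(CC)(CC)c1ccc(OCS(=O)(=O)c2ccccc2)c(C)c1` — > 50000 nM
compound 2 `CCn1c(C(=O)N[C@H](CO)CCO)ccc1C(CC)(CC)c1ccc(OCS(=O)(=O)c2ccccc2)c(C)c1` — 15900 nM
compound 3 `CCn1c(C(=O)N[C@@H](CO)CCCO)ccc1C(CC)(CC)c1ccc(OCS(=O)(=O)c2ccccc2)c(C)c1` — 16400 nM

The three compounds share one core and differ only in the group on the amide-type nitrogen. In a functional assay on BXPC-3 cells (Homo sapiens) for antiproliferative activity, read by MTT assay, with a stated time of 24 h (on this read-out higher numbers stand for weaker inhibition and lower numbers for stronger inhibition), compound 1 gives only a limit, > 50000 nM; it sits at the limit of > 50000 nM in this assay, at which 1 of the 3 values shown sits, and no number is known for it. Compound 2 gives 15900 nM in this assay. Compound 3 gives 16400 nM in this assay. The two diol-bearing compounds are indistinguishable from each other, a 1.0-fold higher number from compound 2 to compound 3 (0.01 log units; within the scatter), while both steps away from compound 1 read as at least modest gains: an at least 3.1-fold lower number from compound 1 to compound 2 (0.49 log units; beyond the scatter) and an at least 3.0-fold lower number from compound 1 to compound 3 (0.48 log units; beyond the scatter).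

The next compound, compound 4 `CCn1c(C(=O)N[C@H](C)C(=O)O)ccc1C(CC)(CC)c1ccc(OCS(=O)(=O)c2ccccc2)c(C)c1`, changes the same position: 1-carboxyethyl in place of 1,2-bis(methoxycarbonyl)ethyl on an amide-type nitrogen. Both measured steps from compound 1 bear on it, since each also exchanges the 1,2-bis(methoxycarbonyl)ethyl group for a smaller, more polar group on the amide-type nitrogen, and each lowered the number by at least the stated amount. Whether the 1-carboxyethyl group behaves like the diols is not shown by any compound here, so the expectation is hedged toward the limit side. The expected step is an at least 2.0-fold lower number from compound 1 to compound 4 (0.30 log units; that floor lies within the scatter). Compound 4 is estimated at 25000 nM, in the range 8000 nM to 60000 nM.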

Compound 4, half-maximal inhibitory concentration: 20100 nM
The estimate for compound 4 lay 1.2-fold (0.09 log units) above the measured number, and the stated range covers the measured number.
By their numbers in this assay, from the lowest: compounds 2, 3 and 4 (each within the scatter of the next). At a limit, above all of these: compound 1.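

In this assay, the step to the 1-carboxyethyl group on the amide-type nitrogen also reads as at least modest, with an at least 2.4-fold lower number from compound 1 to compound 4 (0.39 log units; beyond the scatter), so the lower number is not confined to the two diol-bearing groups. Compound 4 cannot be told apart from those two compounds, with a 1.3-fold higher number from compound 2 to compound 4 (0.10 log units; within the scatter) and a 1.2-fold higher number from compound 3 to compound 4 (0.09 log units; within the scatter). Among the four groups now shown, compound 2, compound 3 and compound 4 therefore read alike, while compound 1 stands apart as a limit with no number behind it: the limit of > 50000 nM in this assay, at which 1 of the 4 values shown sits.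

On these data alone, the true size of each step from compound 1 stays open, as only a floor is known for it. Also open, as far as these compounds go, is whether a methyl ester of the 1-carboxyethyl group, an amine, or a longer chain ending in a carboxylic acid on the amide-type nitrogen would stay level with compound 2, compound 3 and compound 4 or move beyond the scatter, and what the opposite configuration at the defined stereocentre would give.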